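The compounds below may be only part of what the source reports. "The series", "measured", "known", "first", "only" and "open" are said of these compounds alone.

Compound 1 `COc1ccc(F)cc1N1C(=O)CSC1c1cccc(C(=O)NCCCCn2cccn2)c1` carries a 1H-pyrazol-1-yl group at the end of a four-carbon chain. In an ADME assay on microsomes from liver (Mus musculus) for metabolic stability, read by LC-MS, using NADPH, with a stated time of 10 min, tested at 0.1 uM (on this read-out higher numbers stand for fast clearance and lower numbers for slow clearance), compound 1 gives 1310 mL.min-1.g-1. Compound 2 `COc1ccc(F)cc1N1C(=O)CSC1c1cccc(C(=O)NCCCCc2ccccc2)c1`, with phenyl in place of 1H-pyrazol-1-yl on a saturated chain carbon, four bonds along the chain from an amide-type nitrogen, gives 2250 mL.min-1.g-1 in this assay. The only shown step, a 1.7-fold higher number from compound 1 to compound 2 (0.23 log units; within the scatter), is within the scatter, so compound 1 and compound 2 stand side by side with no separation that can be trusted.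

Compound 3 `O=C(NCCCCn1cccn1)c1cccc(C2SCC(=O)N2c2cc(F)ccn2)c1` differs from compound 1 in another part of the molecule: 4-fluoropyridin-2-yl in place of 5-fluoro-2-methoxyphenyl on an amide-type nitrogen in a ring. No measured step touches the group on the ring amide-type nitrogen, so nothing shown speaks for a shift in this assay in either direction. For compound 3 a value near that of compound 1 is expected, a step of a 1.2-fold lower number from compound 1 to compound 3 (0.08 log units; within the scatter) that stays within the scatter. The estimate for compound 3 is 1100 mL.min-1.g-1, with a range from 500 mL.min-1.g-1 to 2500 mL.min-1.g-1.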

Compound 3, intrinsic clearance in microsomes: 397 mL.min-1.g-1
Estimate against measurement, compound 3: 2.8-fold (0.44 log units) above; the measured number lies below the stated range.
By their numbers in this assay, from the lowest: compound 3; then compounds 1 and 2 (each within the scatter of the next).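

For the compounds shown here, the group on the ring amide-type nitrogen matters in this assay in a way the earlier compounds could not show, since they differed only at the far end of the chain. Here, 4-fluoropyridin-2-yl in place of 5-fluoro-2-methoxyphenyl brings a 3.3-fold lower number from compound 1 to compound 3 (0.52 log units; beyond the scatter) with the rest of the molecule unchanged. This position can therefore move the read-out towards slow clearance, although nothing measured here explains the step.

The swap puts a nitrogen into the ring and removes the methoxy group at once, so the compounds shown cannot tell which of these changes carries the step. Also open, from the compounds shown here alone, is how a plain pyridin-2-yl or a 2-methoxypyridinyl group would read on this nitrogen, and whether the step holds with phenyl at the chain end.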